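This account rests on a few compounds, and the source may have more. Where it says the series, first, only, none or still open, it means among the compounds named here.

Working notes on the series. Within the data shown here, compound 1 `O=CC1CCCCCCCC1` and compound 2 `CCCCC(O)CN` are the two measured members. In an assay on isolated protein for inhibition of Phenylethanolamine N-methyltransferase (Bos taurus) (a lower number here means a stronger inhibitor, a higher number a weaker inhibitor), compound 1 gives 6000 nM. In this assay, among the measured compounds shown here, compound 2 gives 345000 nM, the higher of the two numbers and well apart from compound 1; the two structures differ in more than one place, so no single step connects them and the gap is read only as the two values stand.

Compound 3 `CCCCCCC(O)CN` is not yet measured. It differs from compound 2 by ethyl in place of hydrogen on a saturated chain carbon, five bonds along the chain from an oxygen on a saturated carbon, an extension of the saturated chain with no change to the amine or the hydroxyl. For the measured compounds named here, no measured pair isolates this change, so the direction rests on expectation alone. Compound 3 is expected to come out somewhat stronger than compound 2, with the step from compound 2 to compound 3 estimated at a 2.9-fold lower number from compound 2 to compound 3 (0.46 log units; beyond the scatter), a modest move downward rather than none. For compound 3 in this assay the estimate is 120000 nM, within a range from 40000 nM to 350000 nM.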

Compound 3, half-maximal inhibitory concentration: 109000 nM
Estimate against measurement, compound 3: 1.1-fold (0.04 log units) above; measured number inside the range.
By their numbers in this assay, from the lowest: compound 1; then compound 3; then compound 2.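

In this assay, among these compounds, ethyl in place of hydrogen on a saturated chain carbon, five bonds along the chain from an oxygen on a saturated carbon, gives a 3.2-fold lower number from compound 2 to compound 3 (0.50 log units; beyond the scatter), the first single-place step. This position therefore accepts the extension, and the change in the number comes with the amine and the hydroxyl left as they are. Nothing measured here accounts for the size or direction of this step.

As far as these compounds go, whether a longer chain, such as octyl or decyl, continues this downward move remains open, since a single step fixes no trend along the chain. Also open, from the compounds shown here alone, is how a branched chain, a terminal phenyl ring or a carboxylic acid at this position would compare with ethyl.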